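A few compounds are considered here, and "the series" means these few. Any claim that something is new, unique, unknown or untested is made for them only; others in the source may bear on it.

Compounds measured so far:

Compound 1, `CSC(=O)N1CCC(Oc2ncnc3c2CCN3c2ccc(S(C)(=O)=O)cc2F)CC1`: in a functional assay on CHO-K1 cells for agonist activity at Glucose-dependent insulinotropic receptor (Homo sapiens), read by a luciferase reporter, with a stated time of 5 h (on this read-out higher numbers stand for an effect only at larger amounts of compound and lower numbers for an effect already at smaller amounts), compound 1 gives 251 nM.
Compound 2, `CN(C)S(=O)(=O)N1CCC(Oc2ncnc3c2CCN3c2ccc(S(C)(=O)=O)cc2F)CC1`: in this assay compound 2 gives 398 nM.

Within the data shown here, compound 2 stands beside compound 1 on these two numbers, the only measured pair; the one step between them, a 1.6-fold higher number from compound 1 to compound 2 (0.20 log units; within the scatter), does not separate them beyond the scatter. The untested compound 3, `CC(C)c1noc(N2CCC(Oc3ncnc4c3CCN4c3ccc(S(C)(=O)=O)cc3F)CC2)n1`, keeps the shared core of compound 2 and changes only the group on the ring nitrogen: 3-isopropyl-1,2,4-oxadiazol-5-yl in place of dimethylsulfamoyl on an amine nitrogen in a ring.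

Among the measured compounds shown here, the only measured step that bears on this place is the swap of that same ring-nitrogen substituent, a 1.6-fold higher number from compound 1 to compound 2 (0.20 log units; within the scatter), which stayed within the scatter. For the measured compounds named here, with one step at this position and no example of an aromatic ring there, the expectation for compound 3 is a change no larger than the scatter, in no particular direction: a 1.1-fold lower number from compound 2 to compound 3 (0.06 log units; within the scatter) is expected. Compound 3 is therefore estimated at 350 nM, within a range of 120 nM to 1100 nM.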

Compound 3, half-maximal effective concentration: 79.4 nM
Compound 3: middle estimate off by 4.4-fold (0.64 log units), on the high side; measured number below the stated range.
By their numbers in this assay, from the lowest: compound 3; then compounds 1 and 2 (each within the scatter of the next).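

In this assay, the group on the amine nitrogen in the ring can move the number beyond the scatter: 3-isopropyl-1,2,4-oxadiazol-5-yl in place of dimethylsulfamoyl gives a 5.0-fold lower number from compound 2 to compound 3 (0.70 log units; beyond the scatter), and in place of (methylsulfanyl)carbonyl it gives a 3.2-fold lower number from compound 1 to compound 3 (0.50 log units; beyond the scatter). Among these compounds, the only earlier step at this place, between two groups without a ring, was a 1.6-fold higher number from compound 1 to compound 2 (0.20 log units; within the scatter), so compound 3, with its five-membered aromatic ring, is the first to stand apart from the others on this read-out. Nothing at hand accounts for this difference.

The compounds shown leave open whether the step belongs to the aromatic ring itself or to the isopropyl on it. A methyl or a cyclopropyl in place of the isopropyl, or a pyridine ring in place of the oxadiazole, would bear on that question.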